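Styryl series: swapping the amine on compound 2

The compounds below may be only part of what the source reports. "The series", "measured", "known", "first", "only" and "open" are said of these compounds alone.

In a functional assay on L02 cells (Homo sapiens) for inhibition, read by Griess assay, with stated times of 1 h and 24 h (a higher number here means a weaker inhibitor, a lower number a stronger inhibitor), compound 1 (`COc1cccc(CNc2nc(/C=C/c3ccccc3)nc3ccsc23)c1`) gives > 1000000 nM as a limit of the assay and not a number. Compound 2 (`COc1cc(/C=C/c2nc(NC3CC3)c3sccc3n2)cc(OC)c1OC`) gives > 1000000 nM in this assay as a limit too, so its position is known only as a limit and not as a number. Among the measured compounds shown here, the whole data set amounts to the limit of > 1000000 nM in this assay, at which 2 of the 2 values shown sit, and offers no measured step for comparison.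

Compound 3 (`COc1cc(/C=C/c2nc(N3CCN(C)CC3)c3sccc3n2)cc(OC)c1OC`) carries 4-methylpiperazin-1-yl in place of cyclopropylamino on an aromatic carbon, next to the ring nitrogen of the shared core: 4-methylpiperazin-1-yl in place of cyclopropylamino on an aromatic carbon.

For the measured compounds named here, with no measured step to scale from, no change beyond the scatter is expected in this assay in either direction, and another limit is the likeliest report. The expected step is a number no higher from compound 2 to compound 3 (the limit leaves the size open) on the estimate. Compound 3 is estimated at 1000000 nM with an expected range of 250000 nM to 3000000 nM in this assay.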

Compound 3, half-maximal inhibitory concentration: > 1000000 nM
Compound 3 was reported as a limit (the forecaster's own chance of this, stated with the estimate: 70%); the middle value sits exactly at the limit.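

Compound 2 and compound 3 both stand only as limits, so no step between them can be read in this assay: the limit of > 1000000 nM in this assay, at which 3 of the 3 values shown sit.

The compounds shown leave open whether any amine on the shared core gives a measurable half-maximal inhibitory concentration in this assay.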